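A Chloro Added to Compound 2

The source may report more compounds than this note shows. Statements on the series, on what has been measured and on what is new or still open speak of the compounds shown alone.

Of the compounds shown here, two have been measured so far in a functional assay on P388 cells (Mus musculus) for antiproliferative activity, read by colorimetric assay and MTT assay; a lower number here means a stronger inhibitor, a higher number a weaker inhibitor. There compound 1 (`COc1ccc(S(=O)(=O)Nc2ccc(Cl)c3cc[nH]c23)cc1`) gives 1.1 ug/mL and compound 2 (`O=S(=O)(Nc1cccc2cc[nH]c12)c1ccc(Cl)cc1`) gives 6 ug/mL as the higher of the two numbers, a gap beyond the usual scatter. Compound 2 is thus the weaker inhibitor of this pair. Compound 3 (`O=S(=O)(Nc1ccc(Cl)c2cc[nH]c12)c1ccc(Cl)cc1`) is compound 2 with chloro in place of hydrogen on an aromatic carbon, para to a large group (chloro in place of hydrogen on an aromatic carbon). Within the data shown here, compound 1 (1.1 ug/mL) carries the same chloro, but no measured pair isolates this change. A moderate move toward a lower number, and so a stronger inhibitor, is therefore expected in this assay. The expected size of the change is a 2.4-fold lower number from compound 2 to compound 3 (0.38 log units; beyond the scatter) and remains a tentative estimate. For compound 3 the estimated value is 2.5 ug/mL (range 0.8 ug/mL to 7 ug/mL).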

Compound 3, half-maximal inhibitory concentration: 4.6 ug/mL
Beside the measured number, compound 3's estimate is 1.8-fold (0.26 log units) below it, and the stated range covers the measured number.
By their numbers in this assay, from the lowest: compound 1; then compounds 3 and 2 (each within the scatter of the next).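

In this assay, chloro in place of hydrogen on an aromatic carbon, para to a large group, gives a 1.3-fold lower number from compound 2 to compound 3 (0.12 log units; within the scatter) and so, at this position and with this partner group, makes no difference that stands out from the scatter. Among these compounds, with that chloro present in both compounds, chloro in place of methoxy on an aromatic carbon gives a 4.2-fold higher number from compound 1 to compound 3 (0.62 log units; beyond the scatter) and is the first single change here to go beyond the scatter, which places the gap at the methoxy site rather than at the chloro position. Among the compounds shown here, nothing measured so far offers a reason for either step.

For the compounds shown here, still open is whether compound 1 would keep its number with hydrogen in place of its chloro, the one change that would show if the chloro is silent there too. Also open, on these data alone, is how an amine, a carboxylic acid or a methyl group would fare at either position.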